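A few compounds are considered here, and "the series" means these few. Any claim that something is new, unique, unknown or untested is made for them only; others in the source may bear on it.

Working notes on the series. Compound 1, `NNc1ncnc2[nH]cnc12`, is the parent. In a functional assay on KB cells (Homo sapiens) for cytotoxicity (on this read-out lower numbers stand for higher toxicity in this test and higher numbers for lower toxicity in this test), compound 1 gives 49300 nM. Compound 2, `NNc1nc(N)nc2[nH]cnc12`, carries the change amino in place of hydrogen on an aromatic carbon and in this assay compound 2 gives 1000000 nM. For the measured compounds named here, the step of a 20-fold higher number from compound 1 to compound 2 (1.31 log units; beyond the scatter) is the only measured step of this kind so far.

Compound 3, `CO/N=c1/[nH]cnc2c1ncn2[C@@H]1O[C@H](CO)[C@@H](O)[C@H]1O`, is built on a different core; the difference between the core of compound 1 and the core of compound 3 is not broken down here. In this assay compound 3 gives 6160 nM, the lowest of the three numbers, with compound 1 nearest and compound 2 furthest, both gaps beyond the scatter.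

Compound 4, `CO/N=c1/[nH]c(N)nc2c1ncn2[C@@H]1O[C@H](CO)[C@@H](O)[C@H]1O`, is not yet measured. It differs from compound 3 by amino in place of hydrogen on an aromatic carbon. This is the same kind of change as that from compound 1 to compound 2, and it occurs twice among the compounds shown. The two places are not identical word for word: in compound 1 the carbon is meta to an aminoamino group (2 heavy atoms), whereas in compound 3 it is meta to a group of 3 heavy atoms; in both it lies between two ring nitrogen atoms of a six-membered aromatic ring with 2 nitrogen.

With a single measured step on another core, the expectation for compound 4 is a step of about a 16-fold higher number from compound 3 to compound 4 (1.21 log units; beyond the scatter), resting on a 20-fold higher number from compound 1 to compound 2 (1.31 log units; beyond the scatter). Compound 4 is thus expected to give roughly 100000 nM in this assay. The estimated range for compound 4 runs from 20000 nM to 500000 nM.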

Compound 4, half-maximal cytotoxic concentration: 784000 nM
Compound 4: middle estimate off by 7.8-fold (0.89 log units), on the low side; measured number outside the range, above it.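

In this assay, amino in place of hydrogen on an aromatic carbon gives a 130-fold higher number from compound 3 to compound 4 (2.10 log units; beyond the scatter), so the direction seen on the core of compound 1 is also seen on the core of compound 3, with a higher number and thus lower toxicity in this test on both cores. For the compounds shown here, the direction carried over but the size did not, as the two steps differ by more than their scatter: the same change on two cores in this assay, a 20-fold higher number (1.31 log units; beyond the scatter) from compound 1 to compound 2 and a 130-fold higher number (2.10 log units; beyond the scatter) from compound 3 to compound 4, 6.3-fold (0.80 log units) apart, beyond the scatter of two such steps Two pairs show only that the change went the same way on these two cores; they do not show which of the differences between the cores goes with the larger step, nor how large the step would be on a further core.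

The compounds shown leave open whether the rise in the number belongs to amino itself or would also follow from another group on the same aromatic carbon, such as methylamino, a methyl group or a chlorine atom. They also leave open how the step would fall if a longer chain stood in place of the group of 3 heavy atoms on the core of compound 3.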